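Swapping the Quinone Core: What to Expect for Compound 3

This account rests on a few compounds, and the source may have more. Where it says the series, first, only, none or still open, it means among the compounds named here.

Measured so far:
compound 1 `Cc1ccc(S(=O)(=O)/N=C(/CCNC2=CC(=O)c3ccccc3C2=O)Nc2cccc(C(F)(F)F)c2)cc1`: 84100 nM
compound 2 `COc1ccc(N/C(CCNC2=CC(=O)c3ccccc3C2=O)=N\S(=O)(=O)c2ccc(C)cc2)cc1OC`: 17800 nM

In a functional assay on DU-145 cells (Homo sapiens) for cytotoxicity, read by MTT assay, with a stated time of 48 h (a higher number here means a weaker inhibitor, a lower number a stronger inhibitor), compound 2 gives 17800 nM, the lowest of the two numbers; compound 1 gives 84100 nM, and the step of a 4.7-fold lower number from compound 1 to compound 2 (0.67 log units; beyond the scatter) came from changing the group on the amine nitrogen. Compound 3 `COc1ccc(N/C(CCNC2=CC(=O)C(C)=C(C)C2=O)=N\S(=O)(=O)c2ccc(C)cc2)cc1OC` differs from compound 2 by a group of 10 heavy atoms (8 carbon, 2 oxygen; one six-membered non-aromatic ring of carbon only) in place of a group of 12 heavy atoms (10 carbon, 2 oxygen; one six-membered non-aromatic ring of carbon only, one six-membered aromatic ring of carbon only), on an amine nitrogen. Among the compounds with values here, no measured step touches this part of the structure, so the one step seen offers no guidance on this change. Compound 3 is therefore expected to show a 1.4-fold higher number from compound 2 to compound 3 (0.15 log units; within the scatter), not beyond the scatter. The estimate for compound 3 is 25000 nM, between 6000 nM and 100000 nM.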

Compound 3, half-maximal inhibitory concentration: 14000 nM
The estimate for compound 3 lay 1.8-fold (0.25 log units) above the measured number; measured number inside the range.
By their numbers in this assay, from the lowest: compounds 3 and 2 (each within the scatter of the next); then compound 1.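

Exchanging the group of 12 heavy atoms on the amine nitrogen for the group of 10 heavy atoms removes the six-membered aromatic ring, yet gives a 1.3-fold lower number from compound 2 to compound 3 (0.10 log units; within the scatter) in this assay. This assay therefore does not separate these two groups at this position, so the aromatic ring is not needed to keep this level of cytotoxicity. Nothing available explains this result.

Going by these compounds, it remains open whether a chlorine atom or an amine on the new ring would change the number. Also open, on these data alone, is whether 3-(trifluoromethyl)phenyl would have the same effect alongside this new group.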